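The source may report more compounds than this note shows. Statements on the series, on what has been measured and on what is new or still open speak of the compounds shown alone.

Compound 1 `Fc1ccc(Oc2ccc3c(NCCCNCc4ccco4)ccnc3c2)cc1` is the reference point of the series. In a physicochemical assay for acid dissociation, compound 1 gives 9.28. Compound 3 `COc1cccc(CNCCCNc2ccnc3cc(Oc4ccc(F)cc4)ccc23)c1O` carries the change 2-hydroxy-3-methoxyphenyl in place of furan-2-yl on a saturated chain carbon bound to an amine nitrogen relative to compound 1, and in this assay compound 3 gives 9.28, so that the step of no change at the digits printed from compound 1 to compound 3 (within the scatter) stays inside the usual scatter.

Compound 2 `FC(F)(F)c1cc(-c2ccc3c(NCCCNCc4ccco4)ccnc3c2)cc(C(F)(F)F)c1` shares the same chain and amine end as compound 1 but sits on a different core; the difference between the two cores is not broken down here. In this assay compound 2 gives 9.47, which lies within the scatter of both compound 1 and compound 3.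

Compound 4 `COc1cccc(CNCCCNc2ccnc3cc(-c4cc(C(F)(F)F)cc(C(F)(F)F)c4)ccc23)c1O` has not yet been measured. Against compound 2 it carries the change (2-hydroxy-3-methoxyphenyl in place of furan-2-yl on a saturated chain carbon bound to an amine nitrogen), the same change that turned compound 1 into compound 3, at the same place. Since that change gave no shift in this assay from compound 1 to compound 3 no change at the digits printed from compound 1 to compound 3 (within the scatter), the expected step from compound 2 to compound 4 is likewise small, no change at the digits printed from compound 2 to compound 4 (within the scatter). Compound 4 is therefore estimated at 9.47 in this assay, expected to fall between 9.2 and 9.75.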

Compound 4, acid dissociation constant: 9.47
For compound 4 middle estimate and measured number coincide at the digits printed, and the stated range covers the measured number.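

In this assay, 2-hydroxy-3-methoxyphenyl in place of furan-2-yl on a saturated chain carbon bound to an amine nitrogen gives no change at the digits printed from compound 2 to compound 4 (within the scatter) and, on the core of compound 1, no change at the digits printed from compound 1 to compound 3 (within the scatter) on the same change, so the step reads alike on both cores shown. This is one repeat of the change on a second core, so it shows only that the read-out stays within the scatter in these two pairs; it does not show that the same would hold on a third core or in any other read-out. No measurement is available that bears on why the number stays put.

The compounds shown leave open how this read-out would respond to a carboxylic acid or a tertiary amine at this place, or to a longer chain in place of the present one. They also leave open what a single change on the core would do, as no pair shown isolates one.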